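This account rests on a few compounds, and the source may have more. Where it says the series, first, only, none or still open, it means among the compounds named here.

Measured so far:
- compound 1, `CC(C)(C)C1=NN(c2ccc(C(F)(F)F)cc2)C(c2ccc(O)cc2)C1`, in an assay on U-937 cells for inhibition of protein kinase C zeta type (Homo sapiens), read by reporter gene assay (a lower number here means a stronger inhibitor, a higher number a weaker inhibitor), compound 1 gives "not determined" (no result reported)
- compound 2, `Oc1ccc(C2CC(c3ccccc3O)=NN2c2cccc(Cl)c2)cc1F`, in this assay compound 2 gives "not determined" (no result reported)
- compound 3, `Oc1ccccc1C1=NN(c2cccc(Cl)c2)C(c2cc(F)c(O)c(F)c2)C1`, in this assay compound 3 gives 2500 nM

Going by the values given here, compound 3 therefore stands as the only member of this small set with a number to its name; compound 1 and compound 2 carry no result, so there is nothing to rank it against. Its half-maximal inhibitory concentration marks it as a weak inhibitor in absolute terms.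

Compound 4, `Oc1ccccc1C1=NN(c2cccc(Cl)c2)C(c2ccc(O)c(F)c2F)C1`, has not yet been measured. It is built from the same atoms as compound 3, joined differently: 2,3-difluoro-4-hydroxyphenyl in place of 3,5-difluoro-4-hydroxyphenyl on a saturated ring carbon. Put simply, the two fluorine atoms on the hydroxyphenyl group attached to the saturated ring carbon sit at other positions, while the chlorophenyl and hydroxyphenyl groups on the shared core are unchanged.

Among the compounds with values here, with no step between measured compounds available, the size of this move can only be guessed. A rearrangement of two fluorines on one ring, with donor and acceptor count unchanged, is expected to give little change, none beyond the scatter. Compound 4 is estimated at 3000 nM, within 1000 nM to 10000 nM, which means an expected step of a 1.2-fold higher number from compound 3 to compound 4 (0.08 log units; within the scatter).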

Compound 4, half-maximal inhibitory concentration: 1400 nM
For compound 4 the middle estimate is 2.1-fold (0.33 log units) above the measured one; measured number inside the range.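

In this assay, going by these compounds alone, the pair gives the first step that can be read for this shared core: 2,3-difluoro-4-hydroxyphenyl takes the place of 3,5-difluoro-4-hydroxyphenyl on the saturated ring carbon (a 1.8-fold lower number from compound 3 to compound 4 (0.25 log units; within the scatter)). For this one pair, then, the two fluorine arrangements cannot be told apart, since the step is no larger than the differences expected between repeated measurements of a single compound. No measurement shown here offers a reason for this result or gives a property of either group.

On these data alone, the comparison covers only two fluorine arrangements on a ring that keeps its hydroxyl group, so it remains open what a methoxy group in place of that hydroxyl, or an amine or a carboxylic acid on the same ring, would do to the number. The 3-chlorophenyl and 2-hydroxyphenyl groups are the same in both compounds, so this pair says nothing about how much either of them matters.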